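Propargyl in place of methyl on a fluorinated core

This account rests on a few compounds, and the source may have more. Where it says the series, first, only, none or still open, it means among the compounds named here.

Measured so far:
compound 1, `Cc1nc(O)c2cc(CN(C)c3ccc(C(=O)N[C@@H](CCC(=O)O)C(=O)N(C)[C@@H](CCC(=O)O)C(=O)O)c(F)c3)ccc2n1`, 23 nM
compound 2, `C#CCN(Cc1cc2c(O)nc(C)nc2cc1C)c1ccc(C(=O)N[C@@H](CCC(=O)O)C(=O)N(C)[C@@H](CCC(=O)O)C(=O)O)cc1`, 2.6 nM
compound 3, `Cc1nc(O)c2cc(CN(C)c3ccc(C(=O)N[C@@H](CCC(=O)O)C(=O)N(C)[C@@H](CCC(=O)O)C(=O)O)cc3)c(C)cc2n1`, 8.2 nM

In an assay on L1210 cells for inhibition of Thymidylate synthase (Mus musculus) (a lower number here means a stronger inhibitor, a higher number a weaker inhibitor), compound 1 gives 23 nM, the highest of the three numbers. Compound 3 gives 8.2 nM and compound 2 gives 2.6 nM. The cores of compound 1 and compound 3 differ, but that difference is not broken down here. From compound 3 to compound 2 the change is ethynyl in place of hydrogen on a saturated chain carbon bound to a nitrogen on an aromatic ring, and it made a 3.2-fold lower number from compound 3 to compound 2 (0.50 log units; beyond the scatter). Compound 4, `C#CCN(Cc1ccc2nc(C)nc(O)c2c1)c1ccc(C(=O)N[C@@H](CCC(=O)O)C(=O)N(C)[C@@H](CCC(=O)O)C(=O)O)c(F)c1`, has not yet been measured in this assay; it differs from compound 1 by ethynyl in place of hydrogen on a saturated chain carbon bound to a nitrogen on an aromatic ring, the same change as that from compound 3 to compound 2. Because a 3.2-fold lower number from compound 3 to compound 2 (0.50 log units; beyond the scatter) was beyond the scatter, a step of similar size is expected here, that is a 3.3-fold lower number from compound 1 to compound 4 (0.52 log units; beyond the scatter). The expected value for compound 4 is therefore 7 nM, with a range from 3.5 nM to 15 nM.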

Compound 4, inhibition constant: 4 nM
Estimate against measurement, compound 4: 1.8-fold (0.24 log units) above, and the stated range covers the measured number.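

In this assay, methyl to propargyl on the core of compound 1 gave a 5.8-fold lower number from compound 1 to compound 4 (0.76 log units; beyond the scatter). For the compounds shown here, the change carried from one core to the other with a step of matching size: the same change on two cores in this assay, a 3.2-fold lower number (0.50 log units; beyond the scatter) from compound 3 to compound 2 and a 5.8-fold lower number (0.76 log units; beyond the scatter) from compound 1 to compound 4, 1.8-fold (0.26 log units) apart, within the scatter of two such steps This agreement rests on only two pairs of compounds, so it does not show that the step would hold on any other core, and it gives no reason why the number falls.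

The compounds shown have only methyl or propargyl at this place, which leaves open what an ethyl group, an allyl group or a longer chain would do there. Also open, going by these compounds, is whether the step would persist with chlorine in place of the fluorine of compound 1 and compound 4.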